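Oxazoline ethers: fluoro in place of nitro

The source may report more compounds than this note shows. Statements on the series, on what has been measured and on what is new or still open speak of the compounds shown alone.

The measured compounds, in a toxicity assay on the whole organism with Rattus norvegicus as the target, at a dose of 100 mg/kg by the oral route; on this read-out higher numbers stand for a stronger effect at the one dose given and lower numbers for a weaker effect:
compound 1, `Fc1ccc(OCC2=NCCO2)cc1`, gives 25%;
compound 2, `O=[N+]([O-])c1ccccc1OCC1=NCCO1`, gives 30%;
compound 3, `O=[N+]([O-])c1ccc(OCC2=NCCO2)cc1`, gives 50%.

Compound 2 stands second of the three, and its gap to compound 1 lies within the scatter, while its gap to compound 3 lies beyond it. The difference between the cores of compound 2 and compound 3 is not broken down here.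

One change is seen twice. From compound 3 to compound 1 it is fluoro in place of nitro on an aromatic carbon, and this assay moves by a number 25 percentage points lower from compound 3 to compound 1 (beyond the scatter). Compound 4, `Fc1ccccc1OCC1=NCCO1`, is not yet measured; from compound 2 to compound 4 the change is fluoro in place of nitro on an aromatic carbon. It is the same kind of change, but the place differs: ortho to a group of 7 heavy atoms in compound 4, para to a group of 7 heavy atoms in compound 1.

For compound 4 a step of about a number 20 percentage points lower from compound 2 to compound 4 (beyond the scatter) is expected, resting on compound 1 and compound 3 and their step of a number 25 percentage points lower from compound 3 to compound 1 (beyond the scatter), tempered because compound 2 starts from 30% and the read-out cannot fall far below zero. Compound 4 is therefore estimated at 10%, between 0% and 30%.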

Compound 4, a percentage reported as activity, at one dose (the size of the read-out at that dose, not a potency): 40%
Compound 4: the middle estimate sits 30 percentage points below what was measured; the whole stated range lies below it.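

In this assay fluoro in place of nitro, here ortho to a group of 7 heavy atoms, gives a number 10 percentage points higher from compound 2 to compound 4 (within the scatter) and so does not repeat the earlier step. The two steps differ: the same change on two cores in this assay, a number 25 percentage points lower (beyond the scatter) from compound 3 to compound 1 and a number 10 percentage points higher (within the scatter) from compound 2 to compound 4, 35 percentage points apart, beyond the scatter of two such steps. This shows that in this series the step seen on the core of compound 3 cannot be carried over to the core of compound 2 as it stands, but with one pair on each core it does not show what separates the two steps.

The compounds shown leave open how an amine or a carboxylic acid on that aromatic carbon would read in this assay. They also leave open how a longer chain there would read.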